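The source may report more compounds than this note shows. Statements on the series, on what has been measured and on what is new or still open speak of the compounds shown alone.

Three compounds have been measured so far in an ADME assay on the whole organism (plasma) for pharmacokinetics, with Rattus norvegicus as the target, with a stated time of 6 h, at a dose of 10 mg/kg by the oral route (on this read-out higher numbers stand for higher exposure at the dose given and lower numbers for lower exposure), and stand as follows

compound 1 `O=c1c(OC2CCCC2)c(N2CCN(S(=O)(=O)Cc3ccncc3)CC2)cnn1-c1cc(F)cc(F)c1` gives 20 ng.h/mL
compound 2 `Nc1ccc(CS(=O)(=O)N2CCN(c3cnn(-c4cc(F)cc(F)c4)c(=O)c3OC3CCCC3)CC2)cc1` gives 8100 ng.h/mL
compound 3 `CC1(COc2c(N3CCN(S(=O)(=O)Cc4ccc(N)cc4)CC3)cnn(-c3cccc(Cl)c3)c2=O)CC1` gives 8100 ng.h/mL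

At the digits shown, compound 3 (8100 ng.h/mL) is level with compound 2 (8100 ng.h/mL). Together they hold the top of the three numbers, far over compound 1 (20 ng.h/mL). The next compound, compound 4 `COc1cc(CS(=O)(=O)N2CCN(c3cnn(-c4cccc(Cl)c4)c(=O)c3OCC3(C)CC3)CC2)ccc1N`, departs from compound 3 by one change: methoxy in place of hydrogen on an aromatic carbon (methoxy in place of hydrogen on an aromatic carbon, ortho to an amino group), so that 4-aminophenyl becomes 4-amino-3-methoxyphenyl.

Within the data shown here, only one measured step touches this part of the structure. That step, a 410-fold higher number from compound 1 to compound 2 (2.61 log units; beyond the scatter), is large and beyond the scatter, but it exchanges pyridin-4-yl for 4-aminophenyl. Among the measured compounds shown here, compound 4 keeps the amino group that compound 2 gained, and no measured step adds a group to this ring. The data therefore give neither size nor direction for the methoxy change directly, and a modest step is what is expected, tentatively downward, with a wide margin. The expected change is a 1.5-fold lower number from compound 3 to compound 4 (0.17 log units; within the scatter) in this assay, which is not clearly beyond the scatter. For compound 4 the estimated value is 5500 ng.h/mL, with an expected range from 1500 ng.h/mL to 16000 ng.h/mL.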

Compound 4, area under the concentration-time curve: 13100 ng.h/mL
For compound 4 the middle estimate is 2.4-fold (0.38 log units) below the measured one; the measured number falls inside the stated range.
By their numbers in this assay, from the lowest: compound 1; then compounds 2, 3 and 4 (each within the scatter of the next).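

In this assay, methoxy in place of hydrogen on an aromatic carbon, ortho to an amino group, gives a 1.6-fold higher number from compound 3 to compound 4 (0.21 log units; within the scatter) and so stays within the scatter, which means 4-amino-3-methoxyphenyl cannot be told apart from 4-aminophenyl on this read-out. Among these compounds, the only earlier step in this part of the structure exchanged one ring for another, a 410-fold higher number from compound 1 to compound 2 (2.61 log units; beyond the scatter), whereas this pair shows that the ring can keep its amino group and carry an added methoxy with no change beyond the scatter. Nothing measured here explains this result, and it gives no reason for the number compound 4 reaches.

The compounds shown leave open whether this position would read the same with another group in place of methoxy, such as a fluorine atom, an ethoxy group or a carboxylic acid. Going by these compounds, it also stays open whether methoxy would give a similar step on the core of compound 2, as this change is seen in a single pair, which rests on the core of compound 3.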